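Ester to acid on the cinnamate chain in a pyrazine ester series

A few compounds are considered here, and "the series" means these few. Any claim that something is new, unique, unknown or untested is made for them only; others in the source may bear on it.

Of the compounds shown here, two of a shared core have been measured. Compound 1 `CCOC(=O)/C=C/c1ccccc1OC(=O)c1nc(C)c(C)nc1C` carries the pyrazinecarbonyl ester on an otherwise bare ring; in a functional assay on EA.hy 926 cells (Homo sapiens) for cytotoxicity, read by MTT assay, with stated times of 24 h and 12 h (on this read-out lower numbers stand for an effect already at smaller amounts and higher numbers for an effect only at larger amounts of compound), compound 1 gives 108000 nM. Compound 2 `CCOC(=O)/C=C/c1cc(OC)c(OC(=O)c2nc(C)c(C)nc2C)c(OC)c1` adds two methoxy groups flanking that ester; in this assay compound 2 gives 21400 nM, the lower of the two numbers, and the gap to compound 1 lies beyond the scatter. Among the measured compounds shown here, with only two compounds no trend can be claimed.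

Compound 3 `COc1cc(/C=C/C(=O)O)cc(OC)c1OC(=O)c1nc(C)c(C)nc1C` is the next variation: hydrogen in place of ethyl on an oxygen next to a carbonyl group. For the measured compounds named here, no measured pair in this set shows this change, so its effect on this assay is not known from these data. The working expectation is a step toward a higher number, probably small, and possibly within the scatter; a step toward a lower number is not ruled out. In this assay compound 3 is therefore expected at about 40000 nM, with a range from 12000 nM to 130000 nM, which corresponds to an estimated 1.9-fold higher number from compound 2 to compound 3 (0.27 log units; within the scatter).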

Compound 3, half-maximal effective concentration: 34700 nM
Beside the measured number, compound 3's estimate is 1.2-fold (0.06 log units) above it; the range from low to high includes it.
By their numbers in this assay, from the lowest: compounds 2 and 3 (each within the scatter of the next); then compound 1.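

In this assay, among the compounds shown here, hydrogen in place of ethyl on an oxygen next to a carbonyl group gives a 1.6-fold higher number from compound 2 to compound 3 (0.21 log units; within the scatter) and is the only step here between compounds that differ in one place. At this site, the change from ethoxycarbonyl to carboxy therefore leaves compound 2 and compound 3 indistinguishable on this read-out, so the ethyl group is not shown to be required for the level of effect seen with compound 2, and the free carboxy form is tolerated on the 2-carboxyethenyl chain. Nothing in the data on hand accounts for this outcome, and the result is recorded as an observation only.

Still open, on these data alone, is whether a longer chain on the same oxygen, such as propyl or benzyl, or an amide in place of the ester, would stay within the scatter of compound 2 and compound 3 or move clearly away from them. Also open, as far as these compounds go, is whether the same exchange of ethyl for hydrogen on the core of compound 1, which lacks the two methoxy groups, would give a step of similar size.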